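Replacing an oxygen-linked group with (methylsulfonyl)methyl

A few compounds are considered here, and "the series" means these few. Any claim that something is new, unique, unknown or untested is made for them only; others in the source may bear on it.

Compound 1 `COc1ccc(/C=C/C(=O)c2ccc(OC)c3c2OC(C)(C)C=C3)cc1O` gives 800 nM
Compound 2 `COc1ccc(/C=C/C(=O)c2ccc(OC)c3c2OC(C)(C)C=C3)cc1OC(=O)CCl` gives 450 nM
Compound 3 `COc1ccc(/C=C/C(=O)c2ccc(OC)c3c2OC(C)(C)C=C3)cc1OC(=O)c1ccc(Br)cc1` gives 420 nM

These three compounds share one core and were all tested in a functional assay on A-375 cells (Homo sapiens) for cytotoxicity, read by MTT assay; on this read-out higher numbers stand for weaker inhibition and lower numbers for stronger inhibition. There compound 3 gives 420 nM and cannot be told apart from the other two, since repeated measurements of the same compound would differ by as much as these values do.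

Compound 4 `COc1ccc(/C=C/C(=O)c2ccc(OC)c3c2OC(C)(C)C=C3)cc1CS(C)(=O)=O` has not been measured yet. Going from compound 3 to compound 4, the structure changes as follows: (methylsulfonyl)methyl in place of ((4-bromophenyl)carbonyl)oxy on an aromatic carbon. In words, this is (methylsulfonyl)methyl in place of ((4-bromophenyl)carbonyl)oxy on an aromatic carbon.

Among the compounds with values here, three measured steps bear on this change, each of them a swap on an oxygen on an aromatic ring. They are a 1.8-fold lower number from compound 1 to compound 2 (0.25 log units; within the scatter) and a 1.9-fold lower number from compound 1 to compound 3 (0.28 log units; within the scatter) and also a 1.1-fold lower number from compound 2 to compound 3 (0.03 log units; within the scatter). All three stay within the scatter, and so no large move is expected here. Within the data shown here, compound 4 has no such oxygen, however, and no measured compound carries its new group, so these steps are only a loose guide and the range must be wide.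

The expected change is a 1.4-fold higher number from compound 3 to compound 4 (0.15 log units; within the scatter) and thus no step beyond the scatter.

For compound 4 the estimated value is 600 nM with an expected range from 200 nM to 2000 nM in this assay.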

Compound 4, half-maximal inhibitory concentration: > 10000 nM
Compound 4 ended at the assay's limit (the forecaster's own chance of this, stated with the estimate: 5%); middle value at least 16-fold (1.22 log units) away from the limit.
By their numbers in this assay, from the lowest: compounds 3, 2 and 1 (each within the scatter of the next). At a limit, above all of these: compound 4.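

In this assay the three oxygen-linked groups on this aromatic carbon, hydroxy in compound 1, ((chloromethyl)carbonyl)oxy in compound 2 and ((4-bromophenyl)carbonyl)oxy in compound 3, give values within the scatter of one another, so changes made on that oxygen revealed little about the position. Replacing the whole oxygen-linked group with (methylsulfonyl)methyl, which leaves no oxygen directly on the ring at this place, has a far larger effect, with large steps from all three compounds (an at least 23-fold higher number from compound 3 to compound 4 (1.37 log units; beyond the scatter)) and (an at least 22-fold higher number from compound 2 to compound 4 (1.34 log units; beyond the scatter)) and (an at least 12-fold higher number from compound 1 to compound 4 (1.09 log units; beyond the scatter)). The reading for compound 4 is a limit of the assay and not a number, so these steps give only the least size of the change: the limit of > 10000 nM in this assay, at which 1 of the 4 values shown sits.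

Compound 4 loses the oxygen on the ring and gains the sulfonyl group in one change, so the compounds shown cannot say which of the two goes with the loss of activity. A plain methyl group or an amine on the same carbon would help to separate these two changes.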